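Adding a second chloro to compound 3

A few compounds are considered here, and "the series" means these few. Any claim that something is new, unique, unknown or untested is made for them only; others in the source may bear on it.

Measured so far in a functional assay on J774 cells (Mus musculus) for cytotoxicity; on this read-out higher numbers stand for weaker inhibition and lower numbers for stronger inhibition
- compound 1 `CCCN(CCC)c1c([N+](=O)[O-])cc(S(=O)(=O)Nc2ccc(Cl)cc2)cc1[N+](=O)[O-]` gives 10000 nM
- compound 2 `CCCN(CCC)c1c([N+](=O)[O-])cc(S(=O)(=O)Nc2cccc(OC)c2)cc1[N+](=O)[O-]` gives 25000 nM
- compound 3 `CCCN(CCC)c1c([N+](=O)[O-])cc(S(=O)(=O)Nc2cccc(Cl)c2)cc1[N+](=O)[O-]` gives 8700 nM

Compound 3 cannot be separated from compound 1, as the data show a 1.1-fold lower number from compound 1 to compound 3 (0.06 log units; within the scatter). It does stand below compound 2, with a 2.9-fold lower number from compound 2 to compound 3 (0.46 log units; beyond the scatter) in this series.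

Compound 4 `CCCN(CCC)c1c([N+](=O)[O-])cc(S(=O)(=O)Nc2ccc(Cl)c(Cl)c2)cc1[N+](=O)[O-]` turns 3-chlorophenyl into 3,4-dichlorophenyl. The change is chloro in place of hydrogen on an aromatic carbon, with chloro in place of hydrogen on an aromatic carbon, ortho to a chloro group and para to a large group.

Going by the values given here, no measured step adds a second chloro. The nearest evidence is a 1.1-fold lower number from compound 1 to compound 3 (0.06 log units; within the scatter), which moves the chloro without a real shift. Among the compounds with values here, the only steps beyond the scatter, a 2.5-fold higher number from compound 1 to compound 2 (0.40 log units; beyond the scatter) and a 2.9-fold lower number from compound 2 to compound 3 (0.46 log units; beyond the scatter), are modest and both involve the methoxy of compound 2. A small move towards a lower number is therefore expected, at most modest and possibly lost in the scatter, with an estimated 1.5-fold lower number from compound 3 to compound 4 (0.16 log units; within the scatter) as the working figure. Compound 4 is estimated at 6000 nM with an expected range from 2500 nM to 14000 nM in this assay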

Compound 4, half-maximal inhibitory concentration: 7200 nM
The estimate for compound 4 lay 1.2-fold (0.08 log units) below the measured number, within the range that was stated.
By their numbers in this assay, from the lowest: compounds 4, 3 and 1 (each within the scatter of the next); then compound 2.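

In this assay, the second chloro, ortho to a chloro group and para to a large group, gives a 1.2-fold lower number from compound 3 to compound 4 (0.08 log units; within the scatter), so this position accepts the added atom without a readable shift. Measured against the other monochloro compound, the result is the same at a 1.4-fold lower number from compound 1 to compound 4 (0.14 log units; within the scatter), which leaves 3,4-dichlorophenyl inseparable from both 3-chlorophenyl and 4-chlorophenyl, while the separation from 3-methoxyphenyl holds at a 3.5-fold lower number from compound 2 to compound 4 (0.54 log units; beyond the scatter). Nothing available bears on the cause of these steps.

The compounds shown leave open whether this position stays as unresponsive to groups other than chloro, such as a carboxylic acid, an amine or a longer alkyl chain. They also leave open whether a third chloro on the same phenyl group would produce a step beyond the scatter.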